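Flipping one ring stereocentre on a weak nicotinic binder

The compounds below may be only part of what the source reports. "The series", "measured", "known", "first", "only" and "open" are said of these compounds alone.

Measured compounds:
compound 1 `CN1CCC[C@H]1[C@H]1COc2cc(N)ccc2O1` in an assay on membranes from Cerebral cortex for displacement of a labelled ligand from Neuronal acetylcholine receptor; alpha4/beta2 (Rattus norvegicus), with a stated time of 5 min (on this read-out lower numbers stand for stronger inhibition and higher numbers for weaker inhibition), gives 74000 nM
compound 2 `CN1CCC[C@H]1[C@@H]1COc2cc(O)ccc2O1` in this assay gives 50000 nM

Compound 2 has the lowest of the two numbers; compound 1 is its nearest neighbour and the two lie within the scatter of each other. Compound 3 `CN1CCC[C@H]1[C@H]1COc2cc(O)ccc2O1` differs from compound 2 only in configuration: the two compounds have the same atoms and bonds and differ only in configuration as drawn: 1 of 2 stereo elements differ; a stereocentre at a saturated ring carbon is drawn R in compound 2 and S in compound 3. Among the measured compounds shown here, no measured pair shows what such a flip does here, so no step beyond the scatter can be foreseen in either direction in this assay. Compound 3 is therefore expected to land near compound 2, at 60000 nM (range 15000 nM to 250000 nM), a step of a 1.2-fold higher number from compound 2 to compound 3 (0.08 log units; within the scatter) being the estimate.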

Compound 3, inhibition constant: 71000 nM
The estimate for compound 3 lay 1.2-fold (0.07 log units) below the measured number, within the range that was stated.
By their numbers in this assay, from the lowest: compounds 2, 3 and 1 (each within the scatter of the next).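

This pair tests the ring stereocentre alone, because of one fact: the fact that compounds 2 and 3 differ only in the configuration as drawn. Redrawing that saturated ring carbon from R to S gives a 1.4-fold higher number from compound 2 to compound 3 (0.15 log units; within the scatter), so in this assay the two configurations cannot be told apart. Hydroxy in place of amino on the aromatic carbon gives a 1.0-fold lower number from compound 1 to compound 3 (0.02 log units; within the scatter), so that swap also shows no difference beyond the scatter.

Going by these compounds, what the same flip does with amino on the aromatic carbon remains open. So does what a methoxy group or a carboxylic acid would do at that carbon.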